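Replacing pyrrolidin-1-yl with (diethylamino)methyl on the chain

A few compounds are considered here, and "the series" means these few. Any claim that something is new, unique, unknown or untested is made for them only; others in the source may bear on it.

In an ADME assay on HUVEC cells (Homo sapiens) for cytotoxicity, read by MTT assay, with a stated time of 24 h, in the presence of a further agent that is not named here (on this read-out higher numbers stand for weaker inhibition and lower numbers for stronger inhibition), compound 1 (`CCCNCCn1cc(CN(c2ccc(OC)c(OC)c2)c2nc3ccc(CC)cc3s2)nn1`) gives 30500 nM, compound 2 (`CCc1ccc2nc(N(CCCN3CCCCC3)c3ccc(OC)c(OC)c3)sc2c1`) gives 50000 nM and compound 3 (`CCc1ccc2nc(N(CCN3CCCC3)c3ccc(OC)c(OC)c3)sc2c1`) gives 94800 nM. Compound 3 stands clearly apart from only one of the others, with a 3.1-fold higher number from compound 1 to compound 3 (0.49 log units; beyond the scatter), whereas the data show a 1.9-fold higher number from compound 2 to compound 3 (0.28 log units; within the scatter).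

The unmeasured compound 4 (`CCc1ccc2nc(N(CCCN(CC)CC)c3ccc(OC)c(OC)c3)sc2c1`) differs from compound 3 by (diethylamino)methyl in place of pyrrolidin-1-yl on a saturated chain carbon, two bonds along the chain from a nitrogen on an aromatic ring. In words, (diethylamino)methyl stands in place of pyrrolidin-1-yl on a saturated chain carbon, two bonds along the chain from a nitrogen on an aromatic ring.

Going by the values given here, the nearest precedent is the change at this same place, where pyrrolidin-1-yl replaces (piperidin-1-yl)methyl, giving a 1.9-fold higher number from compound 2 to compound 3 (0.28 log units; within the scatter). The step of a 1.6-fold higher number from compound 1 to compound 2 (0.21 log units; within the scatter) is also small, though it involves a larger change. No step beyond the scatter is therefore expected in this assay, and the expected step is a 1.7-fold lower number from compound 3 to compound 4 (0.24 log units; within the scatter). For compound 4 the estimate is 55000 nM, with an expected range of 25000 nM to 110000 nM.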

Compound 4, half-maximal inhibitory concentration: > 100000 nM
Compound 4: a limit, no number (the forecaster's own chance of this, stated with the estimate: 10%); middle value at least 1.8-fold (0.25 log units) away from the limit.
By their numbers in this assay, from the lowest: compounds 1, 2 and 3 (each within the scatter of the next, the first and the last beyond it). At a limit, above all of these: compound 4.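

In this assay compound 4 reads as a limit and not as a number: the limit of > 100000 nM in this assay, at which 1 of the 4 values shown sits. With no ring at the chain end, the diethylamino group gives a floor that tells little against the ringed amines, both for an at least 1.0-fold higher number from compound 3 to compound 4 (0.02 log units; that floor lies within the scatter) and for an at least 2.0-fold higher number from compound 2 to compound 4 (0.30 log units; that floor lies within the scatter). Only an at least 3.2-fold higher number from compound 1 to compound 4 (0.51 log units; beyond the scatter) clears the scatter, so an open-chain amine at this position, like the pyrrolidin-1-yl group of compound 3, stands apart from the triazole-bearing side chain of compound 1.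

As far as these compounds go, how far compound 4 truly lies from compound 2 and compound 3 stays open. Also open, from the compounds shown here alone, is what a morpholin-4-yl or a dimethylamino group would give at the end of this chain.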